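Growing the acetyl of compound 1 by one carbon

A few compounds are considered here, and "the series" means these few. Any claim that something is new, unique, unknown or untested is made for them only; others in the source may bear on it.

Compound 1 `CC(=O)N1c2ccccc2CCC1C(=O)Nc1cc(C(F)(F)F)cc(C(F)(F)F)c1`: in a functional assay on NCI-H23 cells (Homo sapiens) for cytotoxicity, read by sulforhodamine B assay, with a stated time of 72 h (a lower number here means a stronger inhibitor of growth, a higher number a weaker inhibitor of growth), compound 1 gives > 70000 nM, which is a limit of the assay and not a number.
Compound 2 `CCCCCCCCC(=O)N1c2ccccc2CCC1C(=O)Nc1ccccc1C(F)(F)F`: in this assay compound 2 gives 4220 nM.
Compound 3 `O=C(Nc1ccccc1C(F)(F)F)C1CCc2ccccc2N1C(=O)c1ccc(Cl)cc1`: in this assay compound 3 gives 307 nM.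

All three share a core carrying an amide on one side and an acyl group on the ring nitrogen on the other. Compound 1 stands at the limit of > 70000 nM in this assay, at which 1 of the 3 values shown sits, so for it only a limit is known, and it cannot be ranked against the other two beyond that. Within the data shown here, the only measured step is a 14-fold lower number from compound 2 to compound 3 (1.14 log units; beyond the scatter), which exchanges the whole acyl group.

Compound 4 `CCC(=O)N1c2ccccc2CCC1C(=O)Nc1cc(C(F)(F)F)cc(C(F)(F)F)c1` differs from compound 1 by methyl in place of hydrogen on a saturated chain carbon bound to a carbonyl carbon. Among the measured compounds shown here, no measured pair tests this kind of change: the step between compound 2 and compound 3 alters the acyl group wholesale rather than lengthening it by one carbon, so it gives no guide to its size or direction. With nothing to suggest a gain and compound 1 already at the limit, no step beyond the scatter is expected, and the assay will most likely again report only a limit.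

Compound 4 is therefore estimated at 80000 nM, within a range of 30000 nM to 300000 nM. That estimate means an expected step that the limit leaves unreadable from compound 1 to compound 4.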

Compound 4, concentration for 50% growth inhibition: 7820 nM
Compound 4: the middle estimate sits 10-fold (1.01 log units) above what was measured; the whole stated range lies above it.
By their numbers in this assay, from the lowest: compound 3; then compounds 2 and 4 (each within the scatter of the next). At a limit, above all of these: compound 1.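

Methyl in place of hydrogen on a saturated chain carbon bound to a carbonyl carbon gives an at least 8.9-fold lower number from compound 1 to compound 4 (0.95 log units; beyond the scatter) in this assay. The earlier compounds shown here showed only a wholesale exchange of the acyl group, whereas this pair shows that adding 1 heavy atom to the acetyl, turning it into propanoyl, is enough to move the number beyond the scatter. Compound 1 stands at a limit and not at a number, so this step is only a minimum and its true size stays unread: the limit of > 70000 nM in this assay, at which 1 of the 4 values shown sits.

Still open, on these data alone, is whether the number keeps falling as the chain grows to butanoyl and beyond, as compound 2 carries a longer chain but also differs from compound 4 on the amide side, so that pair does not test chain length alone. Also open, as far as these compounds go, is what an amine or a phenyl in place of this methyl would do, and whether the step from acetyl to propanoyl would look the same with the amide part of compound 2.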